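A few compounds are considered here, and "the series" means these few. Any claim that something is new, unique, unknown or untested is made for them only; others in the source may bear on it.

The compounds measured so far:

Compound 1, `CCCCc1nc(Cl)c(COC(=O)CCCCO[N+](=O)[O-])n1Cc1ccc(-c2ccccc2-c2nn[nH]n2)cc1`: 100%
Compound 2, `CCCCc1nc(Cl)c(COC(=O)c2cccc(CO[N+](=O)[O-])c2)n1Cc1ccc(-c2ccccc2-c2nn[nH]n2)cc1`: 100%
Compound 3, `CCCCc1nc(Cl)c(COC(=O)c2ccc(C(C)O[N+](=O)[O-])cc2)n1Cc1ccc(-c2ccccc2-c2nn[nH]n2)cc1`: 100%

In a functional assay on the whole organism (aorta, strain Wistar) with Rattus norvegicus as the target (on this read-out higher numbers stand for larger maximal responses and lower numbers for smaller maximal responses), compound 1 gives 100% and stands level with compounds 2 and 3. The three measured steps were all flat: no change at the digits printed from compound 1 to compound 2 (within the scatter), no change at the digits printed from compound 1 to compound 3 (within the scatter) and no change at the digits printed from compound 2 to compound 3 (within the scatter). Each of these swaps kept the carbonyl and the nitrooxy group and only exchanged the piece between them, and none of the exchanges moved the response out of the scatter.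

The next compound is compound 4, `CCCCc1nc(Cl)c(CO[N+](=O)[O-])n1Cc1ccc(-c2ccccc2-c2nn[nH]n2)cc1`. It differs from compound 1 as follows: nitro in place of (4-(nitrooxy)butyl)carbonyl on an oxygen on a saturated carbon. This is a larger cut than any measured step, since the carbonyl and its chain are removed entirely, leaving the nitrooxy group directly on the core. The measured steps bear on it only loosely, as they show the response staying at the top whatever sits beyond the carbonyl. Going by the values given here, with no step going against it, compound 4 is therefore expected to give about 100%, in the range 85% to 105%, meaning an expected step of no change at the digits printed from compound 1 to compound 4 (within the scatter).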

Compound 4, largest response reached (Emax), in percent of the reference or control that the assay uses: 100%
Beside the measured number, compound 4's estimate shows no gap at the digits printed, and the stated range covers the measured number.
By their numbers in this assay, from the lowest: compounds 1, 2, 3 and 4 (each within the scatter of the next).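

In this assay, the cut removes the whole (4-(nitrooxy)butyl)carbonyl and leaves only nitro on the oxygen, and this gives no change at the digits printed from compound 1 to compound 4 (within the scatter). The earlier steps shown here only exchanged the piece between the carbonyl and the nitrooxy group, whereas this one shows that the maximal response stays level with neither the carbonyl nor the chain present, so at this position the ester part is not required for that response. Nothing available here offers an explanation for this flat result.

From the compounds shown here alone, all four compounds carry a nitrooxy group, so it remains open whether the response depends on that group at all. A compound with a plain hydroxyl group on the same saturated carbon, in place of the nitrooxy group, would put that question to the test.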